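The compounds below may be only part of what the source reports. "The series", "measured", "known", "first", "only" and "open" are said of these compounds alone.

Measured compounds: compound 1 `Cc1cc(NC(=O)c2cccc(C(F)(F)F)c2)ccc1NS(=O)(=O)C(F)(F)F` gives 8720 nM in an ADME assay on RAW264.7 cells (Mus musculus) for cytotoxicity, read by MTT assay, with a stated time of 48 h; a higher number here means a weaker inhibitor, a lower number a stronger inhibitor; compound 2 `Cc1cc(NC(=O)c2cc(C(F)(F)F)cc(C(F)(F)F)c2)ccc1NS(=O)(=O)C(F)(F)F` gives 40700 nM in this assay; compound 3 `COc1cc(NC(=O)c2cccc(C(F)(F)F)c2)ccc1NS(=O)(=O)C(F)(F)F` gives 75200 nM in this assay.

The unmeasured compound 4 `COc1cc(NC(=O)c2cc(C(F)(F)F)cc(C(F)(F)F)c2)ccc1NS(=O)(=O)C(F)(F)F` is built from compound 3 by the change (trifluoromethyl in place of hydrogen on an aromatic carbon). The same kind of change has already been made once, from compound 1 to compound 2, as trifluoromethyl in place of hydrogen on an aromatic carbon, and there it gave a 4.7-fold higher number from compound 1 to compound 2 (0.67 log units; beyond the scatter). The two place lines read alike, so the surroundings of the change are the same in both pairs. The cores differ by methoxy in place of methyl on an aromatic carbon, and that difference alone gave an 8.6-fold higher number from compound 1 to compound 3 (0.94 log units; beyond the scatter), so compound 3 starts from a higher number than compound 1; among the three measured compounds its number is the highest, though against compound 2 the gap is within the scatter.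

Among the measured compounds shown here, for compound 4 a step of about a 3.3-fold higher number from compound 3 to compound 4 (0.52 log units; beyond the scatter) is expected, resting on the single earlier step of a 4.7-fold higher number from compound 1 to compound 2 (0.67 log units; beyond the scatter), with the starting point of compound 3 at 75200 nM. The estimate for compound 4 in this assay is 250000 nM, within 80000 nM to 600000 nM.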

Compound 4, half-maximal inhibitory concentration: > 250000 nM
Compound 4: no number, only a limit; the forecaster's own chance of this, stated with the estimate: 30%; the middle value lies on the limit itself.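

In this assay compound 4 gives only a limit of the assay, not a number: the limit of > 250000 nM in this assay, at which 1 of the 4 values shown sits. As far as these compounds go, the trifluoromethyl change gives an at least 3.3-fold higher number from compound 3 to compound 4 (0.52 log units; beyond the scatter), which points the same way as it did on the core of compound 1, but its true size stays unknown: the same change on two cores in this assay, a 4.7-fold higher number (0.67 log units; beyond the scatter) from compound 1 to compound 2 and an at least 3.3-fold higher number (0.52 log units; beyond the scatter) from compound 3 to compound 4; the limit leaves it open whether they differ. The change of methyl to methoxy reads the same way, with an at least 6.1-fold higher number from compound 2 to compound 4 (0.78 log units; beyond the scatter), so both changes carry over from one core to the other in direction, while nothing shows that they carry over in size: the same change on two cores in this assay, an 8.6-fold higher number (0.94 log units; beyond the scatter) from compound 1 to compound 3 and an at least 6.1-fold higher number (0.78 log units; beyond the scatter) from compound 2 to compound 4; the limit leaves it open whether they differ.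

The compounds shown hold only methyl or methoxy at one place and only hydrogen or trifluoromethyl at the other, so they leave open how a chlorine, an ethoxy group or a nitrile would move the number. With each change seen on just two cores, they also leave open whether the same direction would hold on any further core.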